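Losing the hydroxyl on the indanylamine arm of a piperidinylpropyl indole

The source may report more compounds than this note shows. Statements on the series, on what has been measured and on what is new or still open speak of the compounds shown alone.

Compound 1 `c1ccc(C2CCCCN2C2CCN(CCCc3c[nH]c4ccc(-n5cnnc5)cc34)CC2)cc1` and compound 2 `O[C@@H]1Cc2ccccc2[C@H]1NC1CCN(CCCc2c[nH]c3ccc(-n4cnnc4)cc23)CC1` share a core and were tested in an assay on CHO cells for displacement of a labelled ligand from 5-hydroxytryptamine receptor 1B (Homo sapiens); on this read-out higher numbers stand for weaker inhibition and lower numbers for stronger inhibition. In this assay compound 1 gives 410 nM, and compound 2 gives 210 nM; the two numbers lie within the scatter of each other, so neither stands apart. Compound 3 `c1ccc2c(c1)CCC2NCC1CCN(CCCc2c[nH]c3ccc(-n4cnnc4)cc23)CC1` differs from compound 2 in one place: ((2,3-dihydro-1H-inden-1-yl)amino)methyl in place of (2-hydroxy-2,3-dihydro-1H-inden-1-yl)amino on a saturated ring carbon. Among the measured compounds shown here, no measured step of this kind is available, so the step from compound 2 to compound 3 is expected to be small, a 1.9-fold higher number from compound 2 to compound 3 (0.28 log units; within the scatter), leaning towards a slightly higher number. Compound 3 is therefore estimated at 400 nM, with a range of 150 nM to 1200 nM.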

Compound 3, half-maximal inhibitory concentration: 25 nM
The estimate for compound 3 lay 16-fold (1.20 log units) above the measured number; measured number outside the range, below it.
By their numbers in this assay, from the lowest: compound 3; then compounds 2 and 1 (each within the scatter of the next).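

In this assay, replacing (2-hydroxy-2,3-dihydro-1H-inden-1-yl)amino with ((2,3-dihydro-1H-inden-1-yl)amino)methyl gives an 8.4-fold lower number from compound 2 to compound 3 (0.92 log units; beyond the scatter) and is the first step shown beyond the scatter. It shows that the number responds to a change in the arm on this saturated ring carbon. Nothing available accounts for the size of this step.

The change removes the hydroxyl and adds the methyl link together, so the compounds leave open which of the two carries the step. Plain (2,3-dihydro-1H-inden-1-yl)amino on the same carbon would separate them.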